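Chloro for ethyl on the urea chain of compound 3

The compounds below may be only part of what the source reports. "The series", "measured", "known", "first", "only" and "open" are said of these compounds alone.

Three sulfonate esters share one core. Compound 1 `CCCC(=O)Nc1ccc(S(=O)(=O)Oc2ccccc2C(C)C)cc1` gives 950 nM in a functional assay on HT-1080 cells (Homo sapiens) for antiproliferative activity, read by sulforhodamine B assay, with a stated time of 48 h; a lower number here means a stronger inhibitor, a higher number a weaker inhibitor. Compound 2 `CC(C)c1ccccc1OS(=O)(=O)c1ccc(NC(=O)CCCl)cc1` gives 6500 nM, and compound 3 `CCCCCNC(=O)Nc1ccc(S(=O)(=O)Oc2ccccc2C(C)C)cc1` gives 4700 nM; compound 3 thus stands beyond the scatter above compound 1 and within the scatter of compound 2. Compound 4 `CC(C)c1ccccc1OS(=O)(=O)c1ccc(NC(=O)NCCCCl)cc1` differs from compound 3 by chloro in place of ethyl on a saturated chain carbon, three bonds along the chain from an amide-type nitrogen. For the measured compounds named here, the closest precedent is the chloro swap on the amide chain, a 6.8-fold higher number from compound 1 to compound 2 (0.84 log units; beyond the scatter), which weakened inhibition; the urea itself cost a 4.9-fold higher number from compound 1 to compound 3 (0.69 log units; beyond the scatter). A modest weakening is therefore expected, a 1.9-fold higher number from compound 3 to compound 4 (0.28 log units; within the scatter), though the scatter could hide it. Compound 4 is estimated at 9000 nM, within 3500 nM to 25000 nM.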

Compound 4, half-maximal inhibitory concentration: 2700 nM
The estimate for compound 4 lay 3.3-fold (0.52 log units) above the measured number, outside the stated range (below it).
By their numbers in this assay, from the lowest: compound 1; then compounds 4, 3 and 2 (each within the scatter of the next, the first and the last beyond it).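

Chloro in place of ethyl, three bonds along the chain from an amide-type nitrogen, leaves compound 4 within the scatter of compound 3 (a 1.7-fold lower number from compound 3 to compound 4 (0.24 log units; within the scatter)), so the clear penalty seen with chloro on the amide chain does not recur on this urea chain. (3-Chloropropyl)amino on the carbonyl carbon does better than 2-chloroethyl (a 2.4-fold lower number from compound 2 to compound 4 (0.38 log units; beyond the scatter)) but falls short of propyl (a 2.8-fold higher number from compound 1 to compound 4 (0.45 log units; beyond the scatter)). Nothing measured here explains these steps.

On these data alone, whether a terminal amine, a hydroxyl or a longer chain would be tolerated on the urea stays open, as does the effect of a shorter chloroalkyl urea.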